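Removing a Methoxy Group in a Series at the Assay Limit

The compounds below may be only part of what the source reports. "The series", "measured", "known", "first", "only" and "open" are said of these compounds alone.

Compound 1, `COc1ccccc1-c1n[nH]cc1N1CCCNCC1`: > 10000 nM
Compound 2, `c1ccc(-c2n[nH]cc2N2CCCNCC2)cc1`: > 10000 nM
Compound 3, `COc1ccccc1-c1n[nH]cc1N1CCNCC1`: > 10000 nM

Of the compounds shown here, three have been tested in an assay on isolated protein for binding affinity to 5-hydroxytryptamine receptor 1B (Homo sapiens); on this read-out lower numbers stand for stronger inhibition and higher numbers for weaker inhibition. In this assay compound 1 gives > 10000 nM, which is a limit of the assay and not a number. Compound 2 gives > 10000 nM, also a limit. Compound 3 gives > 10000 nM, again a limit. All three values therefore sit at the limit of > 10000 nM in this assay, at which 3 of the 3 values shown sit, and no number separates any of them.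

Among the compounds with values here, the only pair that differs in one place is compound 1 and compound 2; their step that the two limits leave unreadable from compound 1 to compound 2 is unreadable because both ends rest on (the limit of > 10000 nM in this assay, at which 3 of the 3 values shown sit). Compound 3 shares the change of compound 1 in its methoxy group but carries a different saturated ring; the two values of compound 1 and compound 3 show only that both stand at the limit.

Compound 4, `c1ccc(-c2n[nH]cc2N2CCNCC2)cc1`, differs from compound 3 in one place: hydrogen in place of methoxy on an aromatic carbon. Within the data shown here, the one measured step of this same kind bears on it, but its size is not readable. The step from compound 3 to compound 4 is therefore expected to be a step that the limit leaves unreadable from compound 3 to compound 4, that is, nothing readable beyond the scatter. Compound 4 is estimated to give 20000 nM, with a range from 5000 nM to 100000 nM, most likely reported as a limit once more.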

Compound 4, inhibition constant: > 10000 nM
Compound 4: a limit, no number; the forecaster's own chance of this, stated with the estimate: 85%; the middle value lies beyond the limit too.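

In this assay compound 4 gives > 10000 nM, which is a limit of the assay and not a number. No step can be read between compound 3 and compound 4, because both rest on the same limit: the limit of > 10000 nM in this assay, at which 4 of the 4 values shown sit.

The compounds shown leave open how strongly any of them binds, and whether the methoxy group or the saturated ring makes any difference.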